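The source may hold more compounds than are shown below. What is called first, only, known or untested is meant among the compounds shown, and "the series" means these compounds.

Measured compounds in an ADME assay on MDBK cells (Bos taurus) for cytotoxicity, read by MTT assay, with a stated time of 96 h; on this read-out higher numbers stand for lower toxicity in this test and lower numbers for higher toxicity in this test:

- compound 1, `COc1ccc(-c2nc3cc(Cl)c(Cl)cc3[nH]2)c(N)c1`, gives 6500 nM
- compound 2, `O=C(CN1CCCCC1)Nc1ccc(-c2nc3cc(Cl)c(Cl)cc3[nH]2)cc1`, gives 45000 nM
- compound 3, `CC(=O)Nc1ccc(-c2nc3cc(C(F)(F)F)ccc3[nH]2)cc1`, gives 50000 nM

Compound 2 stands second highest of the three numbers in this assay. Compound 3 sits close to it, within the usual scatter, so no order between these two can be read. Compound 1 stands clearly apart, its number being the lowest of the set and beyond the scatter from compound 2.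

The next compound, compound 4, `Nc1ccc(-c2nc3cc(Cl)c(Cl)cc3[nH]2)cc1`, is not yet measured. It differs from compound 2 in one place: hydrogen in place of ((piperidin-1-yl)methyl)carbonyl on a nitrogen on an aromatic ring. The shared core and the aromatic ring bearing the nitrogen are kept; only the group on that nitrogen is gone.

Among the measured compounds shown here, no step between two measured compounds that differ in one place is available, so the expected size of the step rests on the spread of the three numbers. Compound 1, which also carries a free amino group, gives 6500 nM, and this is taken as a hint that the number for compound 4 may move downward, possibly beyond the scatter, rather than staying near compound 2. The step from compound 2 to compound 4 is therefore estimated at a 2.3-fold lower number from compound 2 to compound 4 (0.35 log units; beyond the scatter). For compound 4 in this assay the estimate is 20000 nM, with a range from 5000 nM to 60000 nM.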

Compound 4, half-maximal cytotoxic concentration: 7500 nM
Estimate against measurement, compound 4: 2.7-fold (0.43 log units) above, and the stated range covers the measured number.
By their numbers in this assay, from the lowest: compounds 1 and 4 (each within the scatter of the next); then compounds 2 and 3 (each within the scatter of the next).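

In this assay, taking the ((piperidin-1-yl)methyl)carbonyl group off the nitrogen on the aromatic ring, with hydrogen entering in its place, gives a 6.0-fold lower number from compound 2 to compound 4 (0.78 log units; beyond the scatter). Among the compounds shown here, this is the first one-place step, and it shows that the group on this nitrogen is not silent on this read-out: the free amine goes with the lower number, and so with higher toxicity in this test. Nothing measured here explains the step or shows which part of the departing group carries it.

The compounds shown leave open whether the step follows the carbonyl on the nitrogen or the piperidine ring, which a plain acetyl on this nitrogen over the same shared core, or a morpholine ring in place of the piperidine ring, would separate. Also open, going by these compounds, is how the number responds to a longer chain between the carbonyl and the ring, and this single step gives no sign of whether the same change would have a similar size on another core.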